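The source may report more compounds than this note shows. Statements on the series, on what has been measured and on what is new or still open speak of the compounds shown alone.

Working notes on the series. Compound 1 `Cc1c(OCCCCOc2ccc(C(=O)O)c(F)c2)ccc(C(=O)CC(C)(C)C)c1O` gives 80 nM in an assay for positive allosteric modulation of metabotropic glutamate receptor 2 (Rattus norvegicus); a lower number here means that less compound is needed, a higher number that more compound is needed for the effect. Compound 2 `COc1cc(C(=O)O)ccc1OC[C@H](C)COc1ccc(C(=O)CC(C)(C)C)c(O)c1C` gives 28 nM in this assay. Going by the values given here, compound 3 `Cc1cc(C(=O)O)ccc1OC[C@H](C)COc1ccc(C(=O)CC(C)(C)C)c(O)c1C` gives 446 nM in this assay, the highest of the three numbers so far; the nearest is compound 1, the furthest compound 2. Among the compounds with values here, the one single-point step measured runs a 16-fold higher number from compound 2 to compound 3 (1.20 log units; beyond the scatter), a change on the ring that carries the carboxylic acid.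

Compound 4 `Cc1cc(OC[C@H](C)COc2ccc(C(=O)CC(C)(C)C)c(O)c2C)ccc1C(=O)O` keeps every atom of compound 3 and only shifts the methyl on that same ring: 4-carboxy-3-methylphenyl in place of 4-carboxy-2-methylphenyl on an oxygen on a saturated carbon. Within the data shown here, no measured pair moves a group from one ring carbon to another, so the step from compound 2 to compound 3 is the only neighbouring information, and it shows that this ring tolerates little in this assay. It does not tell the direction for a move of the methyl. A modest change, either way, with a wide range is the working expectation. Compound 4 is estimated at 300 nM in this assay, with a range of 70 nM to 1300 nM, meaning an expected step of a 1.5-fold lower number from compound 3 to compound 4 (0.17 log units; within the scatter).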

Compound 4, half-maximal effective concentration: 305 nM
Estimate against measurement, compound 4: 1.0-fold (0.01 log units) below; low and high end bracket the measured number.
By their numbers in this assay, from the lowest: compound 2; then compound 1; then compounds 4 and 3 (each within the scatter of the next).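

In this assay, the swap of 4-carboxy-2-methylphenyl for 4-carboxy-3-methylphenyl on an oxygen on a saturated carbon gives a 1.5-fold lower number from compound 3 to compound 4 (0.17 log units; within the scatter), so the two methyl isomers cannot be told apart in this assay. Moving the methyl around this ring thus has no measurable effect in this pair, whereas exchanging a methoxy for a methyl gave a 16-fold higher number from compound 2 to compound 3 (1.20 log units; beyond the scatter); on the ring that carries the carboxylic acid, the only large step so far is the one that alters the group itself, although a single pair of each kind sets no rule. Nothing measured here bears on why the methyl shift leaves the number within the scatter.

The compounds shown leave open whether the insensitivity seen for the methyl in compound 3 and compound 4 extends to other groups, such as a chlorine, an ethoxy or a hydroxyl, on that ring. They also leave open how a ring with no methyl at all would compare, and whether an amide or a tetrazole could stand in place of the carboxylic acid.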